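The compounds below may be only part of what the source reports. "The series", "measured", "known", "first", "only" and "open" are said of these compounds alone.

In a functional assay for inhibition, read by spectrophotometry, with a stated time of 60 min (on this read-out lower numbers stand for stronger inhibition and higher numbers for weaker inhibition), compound 1 `CC(=O)N1CCN(c2ccc3nnc(-c4cccc(C)c4)n3n2)CC1` gives 28.6 ug/mL. Compound 2 `Cc1cccc(-c2nnc3ccc(N4CCN(C(=O)OC(C)(C)C)C(Cc5ccccc5)C4)nn23)c1` gives 15.8 ug/mL, which lies within the usual scatter of the value for compound 1. Compound 3 `Cc1cccc(-c2nnc3ccc(N4CCN(C(c5ccccc5)c5ccccc5)CC4)nn23)c1` gives 1.75 ug/mL, a number lower than that of compound 1 by more than the scatter. Compound 4 `COc1ccc(N2CCN(c3ccc4nnc(-c5cccc(C)c5)n4n3)CC2)cc1` has not yet been measured. It differs from compound 1 by 4-methoxyphenyl in place of acetyl on an amine nitrogen in a ring, with 4-methoxyphenyl in place of acetyl on an amine nitrogen in a ring. For the measured compounds named here, no measured pair shows this change alone. Compound 3, at 1.75 ug/mL, also has aromatic rings where compound 1 has acetyl, which suggests a moderate move towards stronger inhibition in this assay. The expected step is a 3.6-fold lower number from compound 1 to compound 4 (0.55 log units; beyond the scatter). For compound 4 the estimated value is 8 ug/mL, with an expected range from 2.5 ug/mL to 25 ug/mL.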

Compound 4, half-maximal inhibitory concentration: 45.9 ug/mL
For compound 4 the middle estimate is 5.7-fold (0.76 log units) below the measured one; measured number outside the range, above it.
By their numbers in this assay, from the lowest: compound 3; then compounds 2, 1 and 4 (each within the scatter of the next, the first and the last beyond it).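

In this assay, 4-methoxyphenyl in place of acetyl on an amine nitrogen in a ring gives a 1.6-fold higher number from compound 1 to compound 4 (0.21 log units; within the scatter) and so brings no measurable gain in inhibition. An aromatic ring at this nitrogen is therefore not enough on its own to match compound 3 at 1.75 ug/mL in this series, since compound 4 gives 45.9 ug/mL with a single such ring. As far as these compounds go, whether an unsubstituted phenyl, a benzyl or a benzoyl group at this nitrogen would read like compound 4 or like compound 3 remains open. No measurement shown gives a reason for this result.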